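Trimethoxyphenyl pyrazole enones: varying the aryl ketone

A few compounds are considered here, and "the series" means these few. Any claim that something is new, unique, unknown or untested is made for them only; others in the source may bear on it.

Measured so far in a functional assay on MOLT-4 cells (Homo sapiens) for cytotoxicity, read by sulforhodamine B assay, with a stated time of 48 h, tested at 10 uM; on this read-out lower numbers stand for a stronger effect and higher numbers for a weaker effect at the one concentration tested:
compound 1, `COc1cc(-c2cc(/C=C/C(=O)c3ccc(N)cc3)[nH]n2)cc(OC)c1OC`, gives -5%
compound 2, `COc1ccc(C(=O)/C=C/c2cc(-c3cc(OC)c(OC)c(OC)c3)n[nH]2)cc1`, gives -20%

Within the data shown here, compound 2 stands lowest of the two numbers in this assay; the only other compound, compound 1, is a number 15 percentage points lower from compound 1 to compound 2 (beyond the scatter) away, so that step, from amino to methoxy on the aromatic carbon of the aryl ketone ring, is the single measured change available.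

Compound 3, `COc1cc(-c2cc(/C=C/C(=O)c3ccc(F)c(F)c3)[nH]n2)cc(OC)c1OC`, changes the same ring region more deeply: 3,4-difluorophenyl in place of 4-methoxyphenyl on a carbonyl carbon. Among the measured compounds shown here, the one measured step touched a substituent on this ring and moved the read-out modestly, but no step replaces the whole ring, so the direction for compound 3 is open. A modest move of either sign is as likely as none, and the expected step of a number 8 percentage points higher from compound 2 to compound 3 (within the scatter) is set near zero with a wide range. Compound 3 is therefore estimated at -12% in this assay, between -35% and 12%.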

Compound 3, a percentage reported as activity, at one concentration (the size of the read-out at that concentration, not a potency): -4%
For compound 3 the middle estimate is 8 percentage points below the measured one; the measured number falls inside the stated range.
By their numbers in this assay, from the lowest: compound 2; then compounds 1 and 3 (each within the scatter of the next).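

Replacing the whole aryl ring on the carbonyl carbon moves the read-out in this assay: 3,4-difluorophenyl in place of 4-methoxyphenyl gives a number 16 percentage points higher from compound 2 to compound 3 (beyond the scatter), so this position responds to a full ring exchange and not only to a change of substituent. Against 4-aminophenyl, the same 3,4-difluorophenyl ring gives a number 1 percentage points higher from compound 1 to compound 3 (within the scatter), which leaves compound 1 and compound 3 indistinguishable and compound 2, with 4-methoxyphenyl, alone at the lowest number of the three. Nothing available explains this separation.

On these data alone, whether the lower number is particular to methoxy stays open, and an ethoxy or hydroxyl group on the same ring could test that. How far the result carries to a ring other than phenyl on the carbonyl carbon, such as pyridyl or thienyl, also remains unresolved.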